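A few compounds are considered here, and "the series" means these few. Any claim that something is new, unique, unknown or untested is made for them only; others in the source may bear on it.

Working notes, series on an assay for inhibition of mitogen-activated protein kinase kinase kinase 14 (Homo sapiens), read by luminescence and ADP-Glo, with a stated time of 120 min, in the presence of a further agent that is not named here; on this read-out lower numbers stand for stronger inhibition and higher numbers for weaker inhibition. In this assay, among the compounds with values here, compound 2 `OC1(C#Cc2ccc3nccc(-c4cn[nH]c4)c3c2)CCCCC1` gives 6050 nM, the highest of the two numbers in hand; compound 1 `CC(O)(C#Cc1ccc2nccc(-c3cn[nH]c3)c2c1)c1cccs1` gives 524 nM, and the only measured step is a 12-fold higher number from compound 1 to compound 2 (1.06 log units; beyond the scatter). Compound 3 `OC1(C#Cc2ccc3nccc(-c4cn[nH]c4)c3c2)CCCC1` differs from compound 2 by 1-hydroxycyclopentyl in place of 1-hydroxycyclohexyl on a triple-bonded carbon. Within the data shown here, no measured step covers a change of ring size at this position; the one step in hand concerns a different exchange and does not bear on it. A step within the scatter is therefore expected, a 1.1-fold lower number from compound 2 to compound 3 (0.04 log units; within the scatter). Compound 3 is estimated at 5500 nM, with a range from 2000 nM to 15000 nM.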

Compound 3, half-maximal inhibitory concentration: 564 nM
Estimate against measurement, compound 3: 9.8-fold (0.99 log units) above, outside the stated range (below it).
By their numbers in this assay, from the lowest: compounds 1 and 3 (each within the scatter of the next); then compound 2.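

In this assay, the ring size on the triple-bonded carbon has a large effect: there is an 11-fold lower number from compound 2 to compound 3 (1.03 log units; beyond the scatter). There is also a 1.1-fold higher number from compound 1 to compound 3 (0.03 log units; within the scatter), so among these three compounds, 1-hydroxycyclohexyl alone stands apart, while 1-hydroxycyclopentyl and 1-hydroxy-1-(thiophen-2-yl)ethyl give matching numbers. No evidence in hand accounts for the gap between the two rings.

From the compounds shown here alone, it remains open whether 1-hydroxycyclobutyl would match 1-hydroxycyclopentyl. The compounds shown also leave open how an amine in place of the hydroxyl on the five-membered ring would read.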